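The source may hold more compounds than are shown below. What is called first, only, known or untested is meant among the compounds shown, and "the series" means these compounds.

Measured compounds:
compound 1 `CC[C@H](C)[C@@H](CN(C(=O)[C@@H]1C[C@H]1c1ccccc1)c1ccc(-c2ccccc2)cc1)NC(C)=O`, 5.8 nM in a functional assay for agonist activity at G protein-coupled receptor 88 (Homo sapiens), read by HTRF and cAMP accumulation; a lower number here means that less compound is needed, a higher number that more compound is needed for the effect
compound 2 `CO[C@H](C)[C@H](N)CN(C(=O)[C@@H]1C[C@H]1c1ccccc1)c1ccc(-c2ccccc2)cc1`, 0.68 nM in this assay
compound 3 `CC[C@H](C)[C@H](N)CN(C(=O)[C@@H]1C[C@H]1c1cccc(OC)c1)c1ccc(-c2ccccc2)cc1`, 3000 nM in this assay

Compound 3 gives the highest number of the three in this assay, so it needs the most compound for the effect. Compound 4 `CC[C@H](C)[C@H](N)CN(C(=O)[C@@H]1C[C@H]1c1cc(F)ccc1F)c1ccc(-c2ccccc2)cc1` differs from compound 3 in one place: 2,5-difluorophenyl in place of 3-methoxyphenyl on a saturated ring carbon. Going by the values given here, none of the measured steps touches this position. Among the compounds with values here, the only single-point step, an 8.5-fold lower number from compound 1 to compound 2 (0.93 log units; beyond the scatter), concerns the chain carbon bound to the amide-type nitrogen, not the ring carbon changed here. Within the data shown here, compound 1 and compound 2 both carry a plain phenyl on that ring carbon and give far lower numbers than compound 3, but each also differs from compound 3 at the chain, so their values show no clean step for the phenyl substituent alone. The expectation for compound 4 is therefore uncertain and wide: the step of a 6.0-fold lower number from compound 3 to compound 4 (0.78 log units; beyond the scatter) is estimated, leaning toward a lower number. Compound 4 is expected to give about 500 nM, within 50 nM to 5000 nM.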

Compound 4, half-maximal effective concentration: 770 nM
The estimate for compound 4 lay 1.5-fold (0.19 log units) below the measured number; the range from low to high includes it.
By their numbers in this assay, from the lowest: compound 2; then compound 1; then compound 4; then compound 3.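

In this assay, going by these compounds alone, the swap of 3-methoxyphenyl for 2,5-difluorophenyl on the saturated ring carbon gives the first clean reading at this position: a 3.9-fold lower number from compound 3 to compound 4 (0.59 log units; beyond the scatter). The earlier step concerned only the chain carbon bound to the amide-type nitrogen, whereas this one shows that the number also moves with the substituted phenyl on the three-membered ring while the chain stays the same. No supporting measurement explains why this change lowers the number.

The swap removes one methoxy group and adds two fluorines at once, so the compounds shown cannot assign the step to either part. Also open, as far as these compounds go, is how this chain would read with a plain phenyl, a chlorophenyl or a pyridyl group on the same ring carbon.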